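Series notes: from compound 3 to compound 4

The source may report more compounds than this note shows. Statements on the series, on what has been measured and on what is new or still open speak of the compounds shown alone.

In a functional assay on HeLa cells (Homo sapiens) for inhibition, read by CCK-8 assay, with a stated time of 48 h (on this read-out lower numbers stand for stronger inhibition and higher numbers for weaker inhibition), compound 1 `COc1ccc(NC(=O)NCCNS(=O)(=O)c2ccc(-c3ccccc3OCc3ccccc3)s2)cc1` gives > 50000 nM, a limit of the assay and not a number. Compound 2 `O=C(NCCNS(=O)(=O)c1ccc(-c2ccccc2OCc2cccc(O)c2)s1)Nc1cc(Cl)cc(Cl)c1`, which carries (3,5-dichlorophenyl)carbamoyl, gives > 50000 nM, also a limit. Among the compounds with values here, compound 3 `O=[N+]([O-])c1ccc(NC(=S)NCCNS(=O)(=O)c2ccc(-c3ccccc3OCc3ccccc3)s2)cc1` gives 7100 nM, the only true number in the set.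

Compound 4 `O=C(NCCNS(=O)(=O)c1ccc(-c2ccccc2OCc2ccccc2)s1)Nc1cc(Cl)cc(Cl)c1` follows from compound 3 by one change: a group of 11 heavy atoms (7 carbon, 1 nitrogen, 1 oxygen, 2 chlorine; one six-membered aromatic ring of carbon only) in place of a group of 12 heavy atoms (7 carbon, 2 nitrogen, 2 oxygen, 1 sulfur; one six-membered aromatic ring of carbon only), on an amine nitrogen. The measured step that bears on it is an at least 7.0-fold lower number from compound 1 to compound 3 (0.84 log units; beyond the scatter). That step reached the group now leaving, so removing the group points toward a higher number in this assay. The entering group is not the one that left in that step, so the comparison is only partial. A step beyond the scatter is expected, and it is estimated as a 4.9-fold higher number from compound 3 to compound 4 (0.69 log units; beyond the scatter). A result reported only as a limit is also expected to be quite possible for compound 4, given (the limit of > 50000 nM in this assay, at which 2 of the 3 values shown sit). The estimate for compound 4 is 35000 nM, with an expected range of 12000 nM to 80000 nM.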

Compound 4, half-maximal inhibitory concentration: > 20000 nM
Compound 4: only a limit was reported; the forecaster's own chance of this, stated with the estimate: 55%; the middle value does not contradict the limit.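

On the amine nitrogen, replacing the group of compound 3 with (3,5-dichlorophenyl)carbamoyl in this assay gives an at least 2.8-fold higher number from compound 3 to compound 4 (0.44 log units; beyond the scatter). Compound 3 therefore stands apart at this place from compound 4 as well as from compound 1, and the dichloro pattern on the ring does not recover what the 4-methoxyphenyl of compound 1 lacks. The steps to compound 4 from compound 1 and from compound 2 cannot be read.

The value of compound 4 is a limit and not a number: the limit of > 20000 nM in this assay, at which 1 of the 4 values shown sits. On these data alone, this change swaps the sulfur, the nitro group and the ring pattern together, so it stays open which of them goes with the lower number of compound 3, and how an amine or a carboxylic acid in place of the nitro group would read.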